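A Methyl Added to the Benzyl Ring of Compound 3

This account rests on a few compounds, and the source may have more. Where it says the series, first, only, none or still open, it means among the compounds named here.

Measured so far:
Compound 1 `Cc1cc(=O)oc2cc(Sc3cccc(Cl)[n+]3[O-])ccc12` gives 24500 nM
Compound 2 `Cc1cc(=O)oc2cc(SCc3ccccn3)ccc12` gives > 35200 nM
Compound 3 `CCc1cc(=O)c2ccc(OCc3ccccc3)c(C)c2o1` gives 24800 nM

In a functional assay on KBVIN cells (Homo sapiens) for antiproliferative activity, read by sulforhodamine B assay, with a stated time of 72 h (on this read-out lower numbers stand for stronger inhibition of growth and higher numbers for weaker inhibition of growth), compound 3 gives 24800 nM, and compound 1 gives 24500 nM; these two numbers lie within the scatter of each other, so neither compound can be set above the other. Compound 2 reaches only a limit of the assay, > 35200 nM, recorded as the limit of > 35200 nM in this assay, at which 1 of the 3 values shown sits. Among the measured compounds shown here, no pair of measured compounds differs in a single place, so no measured step is available.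

Compound 4 `CCc1cc(=O)c2ccc(OCc3cccc(C)c3)c(C)c2o1` differs from compound 3 by methyl in place of hydrogen on an aromatic carbon. For the measured compounds named here, nothing among the measured compounds shows what such a methyl does, so the step from compound 3 to compound 4 is expected to stay within the scatter: a 1.1-fold lower number from compound 3 to compound 4 (0.05 log units; within the scatter). Compound 4 is therefore expected to give about 22000 nM, within a range from 8000 nM to 60000 nM.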

Compound 4, concentration for 50% growth inhibition: 24900 nM
For compound 4 the middle estimate is 1.1-fold (0.05 log units) below the measured one, and the stated range covers the measured number.
By their numbers in this assay, from the lowest: compounds 1, 3 and 4 (each within the scatter of the next). At a limit, above all of these: compound 2.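

In this assay, among the compounds shown here, the change from phenyl to 3-methylphenyl gives the first measured step (a 1.0-fold higher number from compound 3 to compound 4 (0.00 log units; within the scatter)) and shows that a methyl on this aromatic carbon, meta to a large group, leaves the two numbers indistinguishable. Nothing given here bears on why this step is so small. The compounds shown leave open whether an amine or a carboxylic acid on the same aromatic carbon would separate from the hydrogen of compound 3. They also leave open what a longer chain would do there.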